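This account rests on a few compounds, and the source may have more. Where it says the series, first, only, none or still open, it means among the compounds named here.

Measured compounds:
compound 1 `CC1=CC[C@@H]([C@@](C)(O)CCCC(C)(C)NC(=S)N/N=C\c2ccc(C)cc2)CC1`: > 100000 nM
compound 2 `CC1=CC[C@@H]([C@@](C)(O)CCCC(C)(C)NC(=S)N/N=C\c2cccc(Cl)c2)CC1`: 45900 nM

In a functional assay on HT-29 cells (Homo sapiens) for cytotoxicity, read by sulforhodamine B assay (on this read-out higher numbers stand for lower toxicity in this test and lower numbers for higher toxicity in this test), compound 1 gives > 100000 nM, which is a limit of the assay and not a number. In the same assay compound 2 gives 45900 nM, the only number shown in the series. Within the data shown here, the one measured step, an at least 2.1-fold lower number from compound 1 to compound 2 (0.33 log units; beyond the scatter), is the whole evidence on the aromatic substituent; its size is bounded by the limit of > 100000 nM in this assay, at which 1 of the 2 values shown sits.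

Compound 3 `CC1=CC[C@@H]([C@@](C)(O)CCCC(C)(C)NC(=S)N/N=C(/C)c2ccccc2)CC1` differs from compound 2 as follows: a group of 9 heavy atoms (8 carbon, 1 nitrogen; one six-membered aromatic ring of carbon only) in place of a group of 9 heavy atoms (7 carbon, 1 nitrogen, 1 chlorine; one six-membered aromatic ring of carbon only), on an amide-type nitrogen. The group that leaves carries the chlorine; the group that enters has one more carbon and no chlorine. Among the measured compounds shown here, the only step that bears on this change is an at least 2.1-fold lower number from compound 1 to compound 2 (0.33 log units; beyond the scatter), where removing the chlorine for a methyl-bearing ring went with an at least modest rise in the number. A rise of similar size is therefore expected from compound 2 to compound 3, a 1.6-fold higher number from compound 2 to compound 3 (0.21 log units; within the scatter). For compound 3 the expected value in this assay is 75000 nM, within 25000 nM to 200000 nM.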

Compound 3, concentration lethal to 50% of the cells: > 100000 nM
Compound 3 was reported as a limit (the forecaster's own chance of this, stated with the estimate: 40%); middle value at least 1.3-fold (0.12 log units) from the limit.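

In this assay, the change on the amide-type nitrogen gives a second step at this position, an at least 2.1-fold higher number from compound 2 to compound 3 (0.33 log units; beyond the scatter), so among the three compounds shown, only the chlorine-bearing compound 2 gives a number. For compound 3, > 100000 nM is a limit of the assay and not a number. The size of the step is therefore bounded, and the step from compound 1 to compound 3 cannot be read, since both values are limits: the limit of > 100000 nM in this assay, at which 2 of the 3 values shown sit.

As far as these compounds go, whether the lower number follows the chlorine itself or some other feature of the group in compound 2 stays open, and a bromine or a methoxy group on the aromatic ring would bear on this. From the compounds shown here alone, how far compound 1 and compound 3 lie from the limit also stays open.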